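The source may hold more compounds than are shown below. What is called first, only, known or untested is meant among the compounds shown, and "the series" means these compounds.

In an ADME assay on HeLa cells (Homo sapiens) for cytotoxicity, read by sulforhodamine B assay, with a stated time of 48 h, tested at 10 uM (on this read-out lower numbers stand for less inhibition and higher numbers for more inhibition at the one concentration tested (going by the name of the read-out)), three compounds have so far been measured:

Compound 1 `COc1nc2ccc(Br)cc2cc1C(c1ccccc1)n1cc(-c2ccc(Br)cc2)nn1`: 6.92%
Compound 2 `CCCCCCc1cn(C(c2ccccc2)c2cc3cc(Br)ccc3nc2OC)nn1`: -0.97%
Compound 3 `CCCCCc1cn(C(c2ccccc2)c2cc3cc(Br)ccc3nc2OC)nn1`: -9.81%

Compound 1 stands highest of these three numbers. Its nearest neighbour is compound 2, with a number 7.9 percentage points lower from compound 1 to compound 2 (within the scatter), and its furthest is compound 3, with a number 16.7 percentage points lower from compound 1 to compound 3 (beyond the scatter). Between the two chain-bearing compounds the gap is small, with a number 8.8 percentage points lower from compound 2 to compound 3 (within the scatter).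

The next compound to be measured is compound 4 `COc1nc2ccc(Br)cc2cc1C(c1ccccc1)n1cc(-c2ccccc2C(F)(F)F)nn1`. Relative to compound 1 the change is 2-(trifluoromethyl)phenyl in place of 4-bromophenyl on an aromatic carbon.

Both measured steps from compound 1 bear on this position, but in a different way: each of them takes the 4-bromophenyl away and puts a hexyl or pentyl chain in its place, whereas compound 4 keeps a six-membered aromatic ring of carbon only at that carbon and changes what it carries. Among the measured compounds shown here, no measured pair exchanges one such ring for another, so the measured steps give only an indirect guide. Since the larger of them, a number 16.7 percentage points lower from compound 1 to compound 3 (beyond the scatter), was still modest, and the change to compound 4 is smaller in kind, no step beyond the scatter is expected in this assay . Compound 4 is therefore estimated to give 5%, within a range from -8% to 18%. The expected step is a number 1.9 percentage points lower from compound 1 to compound 4 (within the scatter), which lies within the scatter.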

Compound 4, a percentage reported as inhibition, at one concentration (the size of the read-out at that concentration, not a potency): -1.3%
Estimate against measurement, compound 4: 6.3 percentage points above; the measured number falls inside the stated range.
By their numbers in this assay, from the lowest: compounds 3, 4, 2 and 1 (each within the scatter of the next, the first and the last beyond it).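

Among the compounds shown here, this is the first exchange of one six-membered aromatic ring of carbon only for another at this carbon of the five-membered ring, and in this assay it gives a number 8.2 percentage points lower from compound 1 to compound 4 (within the scatter). Replacing either chain with 2-(trifluoromethyl)phenyl also stays inside the usual variation, with a number 8.5 percentage points higher from compound 3 to compound 4 (within the scatter) and a number 0.3 percentage points lower from compound 2 to compound 4 (within the scatter), so compound 4 cannot be separated from any of the other three, although compound 1 and compound 3 do differ beyond the scatter; keeping an aromatic ring at this carbon therefore does not tie the number to that of compound 1, nor does it set compound 4 apart from the compounds with chains. Nothing measured here offers an explanation for these numbers.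

Going by these compounds, whether a plain phenyl, a pyridine ring, or a chain ending in an amine or a carboxylic acid at this carbon would give a step beyond the scatter stays open. On these data alone, it also stays open whether the 2-(trifluoromethyl)phenyl group would give a similar number on a core without the bromine or the methoxy group.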